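Moving one fluorine on a cytotoxicity-silent scaffold

A few compounds are considered here, and "the series" means these few. Any claim that something is new, unique, unknown or untested is made for them only; others in the source may bear on it.

Compound 1 (`CCCCOc1ccccc1C[C@H]1COC(=O)[C@@H]1Cc1ccc(Cl)c(Cl)c1`) gives > 100000 nM
Compound 2 (`O=C1OC[C@H](Cc2ccccc2F)[C@H]1Cc1ccc(Cl)c(Cl)c1`) gives "not determined" (no result reported)

In a functional assay on HeLa cells (Homo sapiens) for cytotoxicity, read by WST assay, with a stated time of 48 h (a higher number here means that more compound is needed for the effect, a lower number that less compound is needed), compound 1 gives > 100000 nM as a limit of the assay, not a number. The entry for compound 2 reads "not determined" (no result reported) and so it has no number of its own. Still unmeasured is compound 3 (`O=C1OC[C@H](Cc2cccc(F)c2)[C@H]1Cc1ccc(Cl)c(Cl)c1`). The step 3-fluorophenyl in place of 2-fluorophenyl on a saturated chain carbon bound to a saturated ring carbon puts 3-fluorophenyl in place of 2-fluorophenyl on a saturated chain carbon bound to a saturated ring carbon. Among the measured compounds shown here, with compound 1 at > 100000 nM as the only guide, no step beyond the usual scatter is expected in this assay for this swap. An estimate for compound 3 is 100000 nM with 40000 nM to 200000 nM as the expected range.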

Compound 3, half-maximal effective concentration: 20000 nM
Compound 3: the middle estimate sits 5.0-fold (0.70 log units) above what was measured, outside the stated range (below it).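

Compound 2 has no reported result, so no step can be read for the change from 2-fluorophenyl to 3-fluorophenyl in compound 3. Going by these compounds, whether moving the fluorine alters the result in this assay stays open.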